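A few compounds are considered here, and "the series" means these few. Any claim that something is new, unique, unknown or untested is made for them only; others in the source may bear on it.

Notes on the cytotoxicity series, an ADME assay on HEK293 cells (Homo sapiens) for cytotoxicity, read by resazurin assay, with a stated time of 48 h; a higher number here means that more compound is tolerated, a lower number that less compound is tolerated.

Compound 1 `O=S(=O)(Nc1ccc(-c2nc3ccccc3o2)cc1)c1cccc(Cl)c1` is known only as a limit: in this assay compound 1 gives > 100000 nM. Compound 2 `O=S(=O)(Nc1ccc(-c2nc3ccccc3o2)cc1)c1cccc(C(F)(F)F)c1` likewise sits at a limit, > 100000 nM. The step that the two limits leave unreadable from compound 1 to compound 2 is therefore not readable, because of the limit of > 100000 nM in this assay, at which 2 of the 3 values shown sit. Compound 3 `Cc1cccc(S(=O)(=O)Nc2ccc3oc(-c4ccccc4)nc3c2)c1`, which carries the sulfonamide on the other side of the shared core, gives a number in this assay, 69000 nM.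

Compound 4 `COc1ccc(Cl)cc1S(=O)(=O)Nc1ccc(-c2nc3ccccc3o2)cc1` differs from compound 1 by methoxy in place of hydrogen on an aromatic carbon, turning 3-chlorophenyl into 5-chloro-2-methoxyphenyl. Within the data shown here, no measured step bears on this change, and both neighbours of the same arrangement sit at the limit, so no step beyond the scatter is expected in this assay. For compound 4 the expected step is a number no higher from compound 1 to compound 4 (the limit leaves the size open), giving an estimate of 100000 nM with a range from 40000 nM to 250000 nM.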

Compound 4, half-maximal cytotoxic concentration: 75000 nM
Estimate against measurement, compound 4: 1.3-fold (0.12 log units) above, and the stated range covers the measured number.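

In this assay, methoxy on this aromatic carbon, ortho to a large group and para to a chloro group, gives an at least 1.3-fold lower number from compound 1 to compound 4 (0.12 log units; that floor lies within the scatter). Compound 4 thus reads as a number, where the other two compounds with this sulfonamide arrangement, compound 1 and compound 2, sit at a limit. The true size of the step stays open because compound 1 has only a limit: the limit of > 100000 nM in this assay, at which 2 of the 4 values shown sit.

The compounds shown leave open what an amine, a carboxylic acid or a longer chain at this position would give. Going by these compounds, whether methoxy would act alike with trifluoromethyl in place of chloro also remains open.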